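A few compounds are considered here, and "the series" means these few. Any claim that something is new, unique, unknown or untested is made for them only; others in the source may bear on it.

Compound 1 `COCCCNc1nccc(-c2c(C)[nH]c3ccccc23)n1` and compound 2 `Cc1[nH]c2ccccc2c1-c1ccnc(Nc2ccc(F)c(F)c2)n1` share one core and differ only in the group carried on a nitrogen attached to that core. In an assay on isolated protein for inhibition of interferon-induced, double-stranded RNA-activated protein kinase (Homo sapiens), read by luminescence, with a stated time of 10 min (a higher number here means a weaker inhibitor, a lower number a stronger inhibitor), compound 1 gives 1500 nM, and compound 2 gives 1500 nM; the step of no change at the digits printed from compound 1 to compound 2 (within the scatter) leaves compound 2 level with compound 1. Compound 3 `Cc1[nH]c2ccccc2c1-c1ccnc(Nc2ccc(F)cc2)n1` differs from compound 2 by hydrogen in place of fluoro on an aromatic carbon. Going by the values given here, the only measured step exchanged the whole group on that nitrogen without moving the number, so it offers little guidance on removing a single fluoro. The expected step of no change at the digits printed from compound 2 to compound 3 (within the scatter) is therefore none beyond the scatter. Compound 3 is expected to give about 1500 nM, between 600 nM and 4000 nM.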

Compound 3, half-maximal inhibitory concentration: 150 nM
Compound 3: middle estimate off by 10-fold (1.00 log units), on the high side; the whole stated range lies above it.
By their numbers in this assay, from the lowest: compound 3; then compounds 1 and 2 (each within the scatter of the next).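

In this assay the change from 3,4-difluorophenyl to 4-fluorophenyl gives a 10-fold lower number from compound 2 to compound 3 (1.00 log units; beyond the scatter). This single fluoro on the ring counts for more than the exchange of the whole group between compound 1 and compound 2, which left them level. The 4-fluorophenyl group also separates from 3-methoxypropyl on the same nitrogen, with a 10-fold lower number from compound 1 to compound 3 (1.00 log units; beyond the scatter) so carrying an aromatic ring there does not alone set the number. Nothing measured here says why.

Open, from the compounds shown here alone, is how a plain phenyl, or a chloro or methoxy in place of the remaining fluoro, would read in this assay.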